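This account rests on a few compounds, and the source may have more. Where it says the series, first, only, none or still open, it means among the compounds named here.

Series notes. Compound 1 `O=C1NCCc2nc(C#Cc3ccccc3)sc21` was run in an assay on HEK293 cells for negative allosteric modulation of metabotropic glutamate receptor 5 (Homo sapiens), read by FLIPR, with a stated time of 1 h; a lower number here means a stronger inhibitor, a higher number a weaker inhibitor. Compound 1 returns only the assay limit there, > 10000 nM. Among the compounds with values here, compound 2 `CCN1CCc2nc(C#Cc3ccccc3)sc2C1` gives 1200 nM in this assay, the single number the set has so far. The other entry, that of compound 1, sits at a limit (the limit of > 10000 nM in this assay, at which 1 of the 2 values shown sits). Compound 3 `O=C(C1CC(F)C1)N1CCc2nc(C#Cc3ccccc3)sc2C1` differs from compound 2 by (3-fluorocyclobutyl)carbonyl in place of ethyl on an amine nitrogen in a ring. Within the data shown here, no measured step exists between any pair, so the step of a 4.0-fold lower number from compound 2 to compound 3 (0.60 log units; beyond the scatter) is an expectation only; it is expected to run toward stronger inhibition and to exceed the scatter. Compound 3 is estimated at 300 nM, within 60 nM to 1500 nM.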

Compound 3, half-maximal inhibitory concentration: > 10000 nM
Compound 3 gave a limit, no number; the forecaster's own chance of this, stated with the estimate: 5%; at least 33-fold (1.52 log units) between middle value and limit.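

On the amine nitrogen in a ring, (3-fluorocyclobutyl)carbonyl in place of ethyl gives, in this assay, an at least 8.3-fold higher number from compound 2 to compound 3 (0.92 log units; beyond the scatter), so this position does not accept this change without weaker inhibition. Compound 3 sits at a limit of the assay, which means the step fixes only a minimum size. Compound 2 remains the only compound here with a number: the limit of > 10000 nM in this assay, at which 2 of the 3 values shown sit.

The compounds shown do not separate the contribution of the carbonyl from that of the fluorinated four-membered ring. An acetyl group, a cyclobutyl group directly on this nitrogen, or a longer alkyl chain there would bear on that question.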